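Swapping the ring-nitrogen substituent in a xenograft inhibition series

The source may report more compounds than this note shows. Statements on the series, on what has been measured and on what is new or still open speak of the compounds shown alone.

Of the compounds shown here, two sharing one core have been tested so far. Compound 1 `CC(C)(O)c1ccc(-c2cnc3c(n2)N(CCC2CCOCC2)C(=O)CN3)cn1` gives 80% in a functional assay on the whole organism (PC-3 cells) for inhibition, with Mus musculus as the target, in a xenograft, with a stated time of 4 h, at a dose of 100 mg/kg by the oral route; a higher number here means more inhibition at the dose given (going by the name of the read-out), a lower number less inhibition. The side group and ring arrangement of compound 1 both differ from those of compound 2 `CO[C@H]1CC[C@@H](N2CC(=O)Nc3ncc(-c4ccc(C(C)(C)O)nc4)nc32)CC1`, and compound 2 gives 54% in this assay. On these two numbers compound 1 stands highest, and its gap to compound 2 lies beyond the usual scatter.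

The next compound, compound 3 `CO[C@H]1CC[C@H](N2C(=O)CNc3ncc(-c4ccc(C(C)(C)O)nc4)nc32)CC1`, keeps the core of compound 1 and changes only the group on the amide-type nitrogen in the ring: 4-methoxycyclohexyl in place of 2-(oxan-4-yl)ethyl on an amide-type nitrogen in a ring.

Among the measured compounds shown here, no step between measured compounds of this kind is available, so the size of this change can only be guessed. The new substituent is the same one that compound 2 carries, though on a differently joined core and with other stereocentres, and compound 2 sits lower than compound 1. A modest downward step is therefore expected, with the estimated change a number 12 percentage points lower from compound 1 to compound 3 (beyond the scatter) running from compound 1 to compound 3 and possibly no larger than the scatter. For compound 3 the expected value in this assay is 68%, within a range of 45% to 85%.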

Compound 3, a percentage reported as inhibition, in the whole organism at one dose (the size of the read-out at that dose, not a potency): 91%
Compound 3: the middle estimate sits 23 percentage points below what was measured; measured number outside the range, above it.
By their numbers in this assay, from the lowest: compound 2; then compound 1; then compound 3.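

Among the compounds shown here, at the amide-type nitrogen in the ring, the first step at this position shows that the 4-methoxycyclohexyl group does more than hold the level set by 2-(oxan-4-yl)ethyl: in this assay the change gives a number 11 percentage points higher from compound 1 to compound 3 (beyond the scatter), a modest gain. The two groups match in heavy atoms, hydrogen-bond donors and acceptors, so the read-out at this position responds to more than those counts; what separates them is a carbon-only ring with a methoxy group and defined stereocentres in place of an oxygen-containing ring on an ethyl chain. Nothing available here accounts for the gain.

The compounds shown leave open whether the gain belongs to the methoxy group, the cyclohexyl ring or its stereochemistry, and on this core only one stereo form of the group appears. They also leave open whether an amine, a carboxylic acid or a simple hydroxyl group in place of the methoxy group would keep the number, and, with a single dose as the read-out, how far any of these differences reflects potency.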